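Adding a Chloro Group to Compound 2

The source may report more compounds than this note shows. Statements on the series, on what has been measured and on what is new or still open speak of the compounds shown alone.

Medicinal chemists often change one small part of a molecule and then measure how a read-out moves. Here the starting point is compound 2 (`c1ccc(C2CCc3nc[nH]c3C2)cc1`). In a physicochemical assay for lipophilicity, at pH 7.4 (on this read-out lower numbers stand for lower lipophilicity and higher numbers for higher lipophilicity), compound 2 gives 2.6. Among the compounds with values here, the only other measured compound is compound 1 (`COCc1ccccc1C1CCc2nc[nH]c2C1`), and in this assay compound 1 gives 2.2; 2.2 (2 entries), which leaves compound 2 with the higher of the two values. Within the data shown here, no measured pair is available that differs in just one place, so no measured step can serve as a guide.

The next compound, compound 3 (`Clc1ccccc1C1CCc2nc[nH]c2C1`), has not yet been measured. It differs from compound 2 in one place: chloro in place of hydrogen on an aromatic carbon. In plain terms, this is chloro in place of hydrogen on an aromatic carbon. Judging from this structural change alone, an upward move larger than the usual scatter of repeat measurements is expected, and the estimated change is a number 0.50 log units higher from compound 2 to compound 3 (beyond the scatter). Compound 3 is therefore expected to read 3.1 in this assay, with an estimated range of 2.7 to 3.5.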

Compound 3, distribution coefficient: 3.1
The estimate for compound 3 equals the measured number at the digits printed; the measured number falls inside the stated range.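

Within the data shown here, compound 3 gives the first measured single-place step in this set: in this assay, putting chloro in place of hydrogen gives a number 0.50 log units higher from compound 2 to compound 3 (beyond the scatter). Before this result, no measured pair could show what one change does at this spot, an aromatic carbon ortho to a group of 9 heavy atoms. It now shows that adding this single chlorine atom at that carbon moves the read-out upward by more than repeat measurements would normally vary, although no supporting measurement is available to explain the rise.

Still open, as far as these compounds go, is whether a fluoro group, a methyl group, an amine or a carboxylic acid on this same carbon would move the number up, move it down or leave it unchanged, and by how much. From the compounds shown here alone, it is also open whether chloro on another carbon of the same ring would give a step of similar size, and one pair of compounds cannot establish a general rule for either question.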